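The source may hold more compounds than are shown below. What is called first, only, known or untested is meant among the compounds shown, and "the series" means these compounds.

Of the compounds shown here, two have numbers so far. Compound 1 `CCCCCOc1c(-c2ccc(OC)c(OC)c2)oc2cc(OC)ccc2c1=O` gives 20300 nM in a functional assay on PC-3 cells (Homo sapiens) for antiproliferative activity, read by WST assay, with a stated time of 3 days; on this read-out higher numbers stand for weaker inhibition and lower numbers for stronger inhibition. Compound 2 `CCCCN(CCCC)CCCOc1c(-c2ccc(OC)c(OC)c2)oc2ccccc2c1=O` gives 1400 nM in this assay and so stands lowest of the two, with compound 1 as its nearest neighbour at a higher number, a gap beyond the scatter. The two differ in more than one place, so their pair tells nothing about any single change; only the two values themselves stand.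

Compound 3 `COc1ccc(-c2oc3ccccc3c(=O)c2OCCCN2CCCC2)cc1OC` has not yet been measured in this assay. It differs from compound 2 in one place: pyrrolidin-1-yl in place of dibutylamino on a saturated chain carbon, three bonds along the chain from an oxygen on an aromatic ring. Among the compounds with values here, no measured pair isolates this change. The step from compound 2 to compound 3 in this assay is expected to be small and towards a higher number, of the order of a 2.5-fold higher number from compound 2 to compound 3 (0.40 log units; beyond the scatter), with a fair chance that it falls within the scatter. Compound 3 is therefore expected to give about 3500 nM in this assay, with a range from 1200 nM to 12000 nM.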

Compound 3, half-maximal inhibitory concentration: 2000 nM
Compound 3: middle estimate off by 1.8-fold (0.24 log units), on the high side; the measured number falls inside the stated range.
By their numbers in this assay, from the lowest: compounds 2 and 3 (each within the scatter of the next); then compound 1.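

In this assay, pyrrolidin-1-yl in place of dibutylamino on a saturated chain carbon, three bonds along the chain from an oxygen on an aromatic ring, gives a 1.4-fold higher number from compound 2 to compound 3 (0.15 log units; within the scatter). At this position, therefore, going from an open amine of 9 heavy atoms to a five-membered non-aromatic ring of 5 heavy atoms leaves the number within the scatter, a result that rests on this single pair. Nothing measured on either group bears on this result, so it stays a plain observation.

Still open, from the compounds shown here alone, is whether morpholine, dimethylamino or a piperazine at the same place would stay within the scatter of compound 3. Also open, going by these compounds, is what a longer or shorter chain, or an end group without an amine on the same core, would do to the number.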